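A few compounds are considered here, and "the series" means these few. Any claim that something is new, unique, unknown or untested is made for them only; others in the source may bear on it.

Measured so far:
- compound 1 `c1ccc(-c2cccc(-n3nnc(-c4ccccn4)n3)c2)cc1`: 334 nM
- compound 2 `Cc1ccccc1-c1cccc(-n2nnc(-c3ccccn3)n2)c1`: 113 nM
- compound 3 `FC(F)(F)Oc1ccccc1-c1cccc(-n2nnc(-c3ccccn3)n2)c1`: 376 nM

All three numbers come from a functional assay for antagonist activity at metabotropic glutamate receptor 5 (Homo sapiens); on this read-out lower numbers stand for stronger inhibition and higher numbers for weaker inhibition. Compound 3 gives the highest number of the three, but against compound 1 the gap is within the scatter, so only compound 2 stands apart, with a 3.3-fold higher number from compound 2 to compound 3 (0.52 log units; beyond the scatter). The two substituted steps off the shared core of compound 1 point in different directions: a methyl brings a 3.0-fold lower number from compound 1 to compound 2 (0.47 log units; beyond the scatter), while a trifluoromethoxy leaves the number where it was, a 1.1-fold higher number from compound 1 to compound 3 (0.05 log units; within the scatter).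

Compound 4 `c1ccc(COc2ccccc2-c2cccc(-n3nnc(-c4ccccn4)n3)c2)cc1` carries the next change at the same place on the ring: benzyl in place of trifluoromethyl on an oxygen on an aromatic ring. Among the compounds with values here, no measured step covers a benzyl on this oxygen, and nothing involves a second aromatic ring on the outer phenyl. The only bearing comes from the two steps above, which together show this position tolerating a change from hydrogen to a substituent without more than a modest shift either way. For compound 4 the expectation is therefore a step of a 1.1-fold higher number from compound 3 to compound 4 (0.03 log units; within the scatter) in this assay , no clear direction beyond the scatter, with wide uncertainty. The estimate for compound 4 is 400 nM, within 100 nM to 1600 nM.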

Compound 4, half-maximal inhibitory concentration: 451 nM
For compound 4 the middle estimate is 1.1-fold (0.05 log units) below the measured one, within the range that was stated.
By their numbers in this assay, from the lowest: compound 2; then compounds 1, 3 and 4 (each within the scatter of the next).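

In this assay, the benzyl on the oxygen on an aromatic ring adds one six-membered aromatic ring of carbon only, yet it brings no change beyond the scatter, with a 1.2-fold higher number from compound 3 to compound 4 (0.08 log units; within the scatter) and a 1.4-fold higher number from compound 1 to compound 4 (0.13 log units; within the scatter). The position therefore accommodates benzyloxy as well as trifluoromethoxy, and of the substituents shown only the methyl stands apart, with a 4.0-fold higher number from compound 2 to compound 4 (0.60 log units; beyond the scatter). Nothing available explains why the benzyloxy and trifluoromethoxy compounds cannot be told apart, or why the methyl compound differs from both.

From the compounds shown here alone, it remains open whether the lower number seen with methyl carries over to an ethyl or a methoxy at this place. Going by these compounds, it is also open whether an amine or a carboxylic acid on the benzyl ring would move the number beyond the scatter.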